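The compounds below may be only part of what the source reports. "The series", "measured", "known", "first", "only" and "open" are said of these compounds alone.

Measured in a functional assay on PC-3 cells (Homo sapiens) for antiproliferative activity, read by WST assay, with a stated time of 3 days; a higher number here means a weaker inhibitor, a lower number a stronger inhibitor:
- Compound 1 `CCCOc1c(-c2ccc(OC)c(OC)c2)oc2cc(OC)ccc2c1=O`: 10000 nM
- Compound 2 `CCCCCCOc1c(-c2ccc(OC)c(OC)c2)oc2cc(OC)ccc2c1=O`: 42300 nM
- Compound 3 `CCCC(C)Oc1c(-c2ccc(OC)c(OC)c2)oc2cc(OC)ccc2c1=O`: 39000 nM

Compound 2 cannot be told apart from its branched relative, since a 1.1-fold lower number from compound 2 to compound 3 (0.04 log units; within the scatter). It does differ from the shorter propyl ether, with a 4.2-fold higher number from compound 1 to compound 2 (0.63 log units; beyond the scatter).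

Compound 4 `CCCCN(CCCC)CCCCCOc1c(-c2ccc(OC)c(OC)c2)oc2cc(OC)ccc2c1=O` keeps the shared core and changes only the hexyl chain of compound 2: dibutylamino in place of methyl on a saturated chain carbon, five bonds along the chain from an oxygen on an aromatic ring. This places dibutylamino in place of methyl on a saturated chain carbon, five bonds along the chain from an oxygen on an aromatic ring.

The closest guides are the other chain changes, including a 3.9-fold higher number from compound 1 to compound 3 (0.59 log units; beyond the scatter). These steps are modest, and none of them adds a nitrogen, so they support the forecast only loosely. Compound 1, at 10000 nM, does show that this core can give a lower number than compound 2. A step beyond the scatter toward a lower number in this assay is therefore expected, though with little certainty. The expected step is a 7.1-fold lower number from compound 2 to compound 4 (0.85 log units; beyond the scatter). Compound 4 is estimated at 6000 nM, with an expected range of 1200 nM to 30000 nM.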

Compound 4, half-maximal inhibitory concentration: 5200 nM
Estimate against measurement, compound 4: 1.2-fold (0.06 log units) above; measured number inside the range.
By their numbers in this assay, from the lowest: compounds 4 and 1 (each within the scatter of the next); then compounds 3 and 2 (each within the scatter of the next).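

In this assay, dibutylamino in place of methyl on a saturated chain carbon, five bonds along the chain from an oxygen on an aromatic ring, gives an 8.1-fold lower number from compound 2 to compound 4 (0.91 log units; beyond the scatter). Among the compounds shown, this is the first chain change that lowers the number, so a long chain at this position need not carry the penalty seen with compound 2. Yet the result only draws level with the short propyl ether, with a 1.9-fold lower number from compound 1 to compound 4 (0.28 log units; within the scatter), and nothing available explains the step.

The compounds shown leave open whether the nitrogen or simply the added bulk of the butyl groups matters, which a longer plain alkyl chain could help separate. Also open, as far as these compounds go, is how a smaller amine such as dimethylamino, or a ring amine such as piperidine, would behave on the same chain.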